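The source may hold more compounds than are shown below. What is called first, only, known or untested is meant among the compounds shown, and "the series" means these compounds.

Compound 1 `O=S(=O)(/C=C/c1ccc(Cl)cn1)c1ccccc1F`: 1040 nM
Compound 2 `O=S(=O)(/C=C/c1cccnc1Cl)c1ccccc1F`: 217 nM
Compound 3 `O=S(=O)(/C=C\c1cccnc1Cl)c1ccccc1F`: 3390 nM

Of the compounds shown here, three have been measured in an assay on U2OS cells for activation of nuclear factor erythroid 2-related factor 2 (Homo sapiens), read by beta-arrestin recruitment, with a stated time of 6 h; a lower number here means that less compound is needed, a higher number that more compound is needed for the effect. Compound 1 gives 1040 nM, compound 2 gives 217 nM and compound 3 gives 3390 nM. For the measured compounds named here, of these three numbers the one for compound 2 is the lowest, and both of the others lie beyond the scatter from it. Going by the values given here, the only single-point step among the measured compounds is a 16-fold higher number from compound 2 to compound 3 (1.19 log units; beyond the scatter), a large change that rests on the fact that compounds 2 and 3 differ only in the configuration as drawn alone.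

Compound 4 `O=S(=O)(/C=C/c1cccnc1Cl)c1ccccc1Cl` is the next compound to be measured in this assay. It differs from compound 2 in one place: chloro in place of fluoro on an aromatic carbon. The double bond keeps the configuration drawn in compound 2. Among the compounds with values here, no measured step touches this kind of change; the step from compound 2 to compound 3 concerns the configuration of the double bond and not the halogen on the ring, so it gives no guidance on size or direction. Without a comparable halogen exchange among the measured compounds, the expected step of a 1.2-fold higher number from compound 2 to compound 4 (0.06 log units; within the scatter) is one not clearly beyond the scatter, in either direction. On that basis compound 4 is estimated at 250 nM, with a range from 90 nM to 700 nM.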

Compound 4, half-maximal effective concentration: 192 nM
The estimate for compound 4 lay 1.3-fold (0.11 log units) above the measured number, within the range that was stated.
By their numbers in this assay, from the lowest: compounds 4 and 2 (each within the scatter of the next); then compound 1; then compound 3.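

At this place, on an aromatic carbon of a six-membered aromatic ring of carbon only and ortho to a large group, chloro in place of fluoro gives a 1.1-fold lower number from compound 2 to compound 4 (0.05 log units; within the scatter) in this assay. For the compounds shown here, this is the first measured step that touches this ring, since the earlier step, a 16-fold higher number from compound 2 to compound 3 (1.19 log units; beyond the scatter), concerned only the double bond; it shows that, with the double bond drawn E, the two halogens cannot be told apart here. Going by these compounds alone, nothing given here accounts for this result, as the only available evidence concerns the double bond and not the halogen.

Going by these compounds, only fluoro and chloro are seen at this place, so it remains open whether a plain hydrogen, a methoxy group, an amine or a carboxylic acid would keep the number in the same region. On these data alone, it is also open whether the halogen exchange would read the same with the double bond drawn Z, as in compound 3, or with the chlorine of the other ring placed as in compound 1.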